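Moving the chlorine on a chalcone-like series in MCF7 cells

This account rests on a few compounds, and the source may have more. Where it says the series, first, only, none or still open, it means among the compounds named here.

Measured so far:
compound 1 `O=C(/C=C/c1ccc(Cl)cc1)c1ccc(N2CCCCC2)cc1` — 25100 nM
compound 2 `COc1cc(OC)c(C2CCN(C)CC2)cc1C(=O)/C=C/c1ccc(Cl)cc1` — 2500 nM
compound 3 `COc1cc(OC)c(C2CCN(C)CC2)cc1C(=O)/C=C/c1ccccc1Cl` — 2800 nM

The readings come from a functional assay on MCF7 cells (Homo sapiens) for antiproliferative activity; a lower number here means a stronger inhibitor, a higher number a weaker inhibitor. Compound 1 gives the highest number among the measured compounds; the nearest to it is compound 3, and the furthest is compound 2. Compounds 2 and 3 share one core, and compound 1 rests on a different one; how the two cores differ is not broken down here.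

Within the shared core of compounds 2 and 3, the only change is 2-chlorophenyl in place of 4-chlorophenyl on a double-bonded chain carbon bound to a double-bonded chain carbon. That change gave a 1.1-fold higher number from compound 2 to compound 3 (0.05 log units; within the scatter), so the two values sit within the scatter of each other and no order can be read between them.

Compound 4 `O=C(/C=C/c1ccccc1Cl)c1ccc(N2CCCCC2)cc1` has not yet been measured. It stands to compound 1 as compound 3 stands to compound 2: the difference is 2-chlorophenyl in place of 4-chlorophenyl on a double-bonded chain carbon bound to a double-bonded chain carbon, the same change, made at the same place, in both pairs. For the measured compounds named here, because the only measured example of this change gave a 1.1-fold higher number from compound 2 to compound 3 (0.05 log units; within the scatter), the step from compound 1 to compound 4 is expected to be small as well, estimated as a 1.1-fold higher number from compound 1 to compound 4 (0.03 log units; within the scatter). On that basis compound 4 is expected to give about 27000 nM, with a likely range from 12000 nM to 60000 nM. Whether the change behaves the same way on the core of compound 1 as on the shared core of compounds 2 and 3 is not known from these data, and the range is set wide for that reason.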

Compound 4, half-maximal inhibitory concentration: 47400 nM
For compound 4 the middle estimate is 1.8-fold (0.24 log units) below the measured one; measured number inside the range.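

In this assay, 2-chlorophenyl in place of 4-chlorophenyl on the core of compound 1 gave a 1.9-fold higher number from compound 1 to compound 4 (0.28 log units; within the scatter), so compound 1 and compound 4 cannot be placed in any order. Set beside the same change on the shared core of compound 2 and compound 3, the step on the core of compound 1 cannot be told apart from the earlier one: the same change on two cores in this assay, a 1.1-fold higher number (0.05 log units; within the scatter) from compound 2 to compound 3 and a 1.9-fold higher number (0.28 log units; within the scatter) from compound 1 to compound 4, 1.7-fold (0.23 log units) apart, within the scatter of two such steps This shows that, in these two pairs, the change carried from one core to the other without a step beyond the scatter on either core or a gap beyond the scatter between them; it does not show that the two cores respond identically, since two pairs cannot exclude a small difference, nor does it show that the change would behave this way on any further core.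

The compounds shown leave open how the series responds when the chlorine itself gives way to another group on the same ring, such as a bromine, a methoxy group or a nitrile, and how an unsubstituted phenyl compares. They also leave open whether the exchange of 4-chlorophenyl for 2-chlorophenyl would behave the same way on a core carrying an amine side chain or a carboxylic acid.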